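Methyl on the shared core: two uracil-type pairs

A few compounds are considered here, and "the series" means these few. Any claim that something is new, unique, unknown or untested is made for them only; others in the source may bear on it.

Measured in a functional assay on MCF7 cells (Homo sapiens) for antiproliferative activity, read by MTT assay, with a stated time of 72 h; on this read-out lower numbers stand for stronger inhibition and higher numbers for weaker inhibition:
compound 1 `COCn1c(CC(COCc2ccccc2)COCc2ccccc2)cc(=O)[nH]c1=O` — > 100000 nM, a limit of the assay, not a number
compound 2 `COCn1c(CC(COCc2ccccc2)COCc2ccccc2)c(C)c(=O)[nH]c1=O` — 72600 nM
compound 3 `C[Si](C)(C)CCOCn1c(CC(O)COCc2ccccc2)cc(=O)[nH]c1=O` — > 100000 nM, a limit of the assay, not a number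

The step of an at least 1.3-fold lower number from compound 1 to compound 2 (0.13 log units; that floor lies within the scatter) comes from methyl in place of hydrogen on an aromatic carbon. Compound 4 `Cc1c(CC(O)COCc2ccccc2)n(COCC[Si](C)(C)C)c(=O)[nH]c1=O`, not yet measured, carries the same kind of change on compound 3: methyl in place of hydrogen on an aromatic carbon. The two place descriptions differ only in that the methyl in compound 2 sits meta to a methoxymethyl group (3 heavy atoms), whereas in compound 4 it sits meta to a group of 8 heavy atoms. The difference between the two cores is not broken down here.

The value of compound 3 is only a limit. Two of the three values sit at the limit of > 100000 nM in this assay, at which 2 of the 3 values shown sit, so the series as a whole is weak in this assay. Compound 4 is expected at 90000 nM, a step of an at least 1.1-fold lower number from compound 3 to compound 4 (0.04 log units; that floor lies within the scatter), since the same kind of change gave an at least 1.3-fold lower number from compound 1 to compound 2 (0.13 log units; that floor lies within the scatter). The outcome may again be reported only as a limit.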

Compound 4, half-maximal inhibitory concentration: > 100000 nM
Compound 4 ended at the assay's limit; the forecaster's own chance of this, stated with the estimate: 55%; at least 1.1-fold (0.04 log units) between middle value and limit.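

In this assay, within the data shown here, compound 4 gives > 100000 nM, a limit of the assay; the value of compound 3 is also a limit, so no step between compound 3 and compound 4 can be read. The compounds shown leave open whether methyl in place of hydrogen on an aromatic carbon changes the number at all on the core of compound 3.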